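A few compounds are considered here, and "the series" means these few. Any claim that something is new, unique, unknown or untested is made for them only; others in the source may bear on it.

Measured compounds and their values in an ADME assay on HUVEC cells (Homo sapiens) for inhibition, read by MTT assay, with a stated time of 48 h; a higher number here means a weaker inhibitor, a lower number a stronger inhibitor:

Compound 1 `COc1cc(/C=N/Nc2nc(-c3ccc(C(F)(F)F)cc3)cs2)c(Br)c(Br)c1OC` gives > 100000 nM, which is a limit of this assay rather than a number.
Compound 2 `COc1cc(/C=N/Nc2nc(-c3cccc(Br)c3)cs2)cc(Br)c1OC` gives > 100000 nM, also a limit.
Compound 3 `COc1cc(/C=N/Nc2nc(-c3ccc(F)c(F)c3)cs2)cc(Br)c1OC` gives > 100000 nM, again a limit.

Compound 3 therefore has no measured number in this assay, only a limit, and the two other values shown are limits as well, so no ordering among the three compounds can be read. Within the data shown here, the one change that is measured, a step that the two limits leave unreadable from compound 2 to compound 3, cannot be sized for the same reason. What stands out is the limit of > 100000 nM in this assay, at which 3 of the 3 values shown sit.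

Compound 4 `COc1cc(/C=N/Nc2nc(-c3ccc(F)c(F)c3)cs2)c(Br)c(Br)c1OC` differs from compound 3 in one place: bromo in place of hydrogen on an aromatic carbon. No measured step carries this exact change, and compound 1, which also carries a second bromo group, sits at the same limit as the others, so nothing shown points to a stronger inhibitor. The expected step that the limit leaves unreadable from compound 3 to compound 4 is none beyond the scatter, with the result most likely remaining a limit. Compound 4 is estimated at 150000 nM in this assay, within 50000 nM to 500000 nM.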

Compound 4, half-maximal inhibitory concentration: 54700 nM
Compound 4: middle estimate off by 2.7-fold (0.44 log units), on the high side; the measured number falls inside the stated range.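

In this assay compound 4 gives 54700 nM, the only actual number among the compounds shown.

The other compounds shown give no such number: the limit of > 100000 nM in this assay, at which 3 of the 4 values shown sit.

Putting a bromo group on the aromatic carbon ortho to the existing bromo group gives an at least 1.8-fold lower number from compound 3 to compound 4 (0.26 log units; that floor lies within the scatter), so a real change at this position is possible but not established. A second bromo group does not by itself bring a number into range, since exchanging only the other aryl group, 3,4-difluorophenyl in place of 4-(trifluoromethyl)phenyl, gives an at least 1.8-fold lower number from compound 1 to compound 4 (0.26 log units; that floor lies within the scatter).

The compounds shown leave open whether a chloro group, a methyl group or an amine on that same carbon would also give a number. From the compounds shown here alone, compound 1 and compound 3 carry limits only, so the true size of either step remains unknown.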